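The compounds below may be only part of what the source reports. "The series", "measured", "known", "first", "only" and "open" are said of these compounds alone.

Measured so far in an assay on isolated protein for inhibition of Amine oxidase [flavin-containing] A (Homo sapiens), read by spectrophotometry; on this read-out higher numbers stand for weaker inhibition and lower numbers for stronger inhibition:
compound 1 `Clc1ccc(/C=N/Nc2nc3ccccc3nc2Cc2ccccc2)cc1` gives 76 nM
compound 2 `C/C(=N\Nc1nc2ccccc2nc1Cc1ccccc1)c1ccc(O)cc1` gives 2.8 nM
compound 3 `C/C(=N\Nc1nc2ccccc2nc1Cc1ccccc1)c1ccc([N+](=O)[O-])cc1` gives 680 nM

Compound 3 stands at the weak end of this set: its number is the highest of the three, with compound 1 nearer to it and compound 2 furthest away. Among the compounds with values here, the one single-point step within the set is a 240-fold higher number from compound 2 to compound 3 (2.39 log units; beyond the scatter), which moves the number sharply upward. Within the data shown here, no step is computed between compound 1 and compound 3; their values simply show compound 1 well below compound 3 on the same read-out.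

Compound 4 `C/C(=N\Nc1nc2ccccc2nc1Cc1ccccc1)c1cccs1` differs from compound 3 by thiophen-2-yl in place of 4-nitrophenyl on a carbon with a double bond to nitrogen. This change removes the nitro-bearing ring entirely and is not the exact reverse of any measured step, but it does leave the nitro group behind, the group whose introduction in a 240-fold higher number from compound 2 to compound 3 (2.39 log units; beyond the scatter) produced the largest step seen. Taking that step as the only direct guide, compound 4 is expected to give a clearly lower number than compound 3, though not to return all the way to the level of compound 2; the hydroxy group present in compound 2 is not restored. The expected step is a 14-fold lower number from compound 3 to compound 4 (1.13 log units; beyond the scatter). Compound 4 is therefore estimated at 50 nM in this assay, with a range from 8 nM to 300 nM.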

Compound 4, half-maximal inhibitory concentration: 64 nM
The estimate for compound 4 lay 1.3-fold (0.11 log units) below the measured number; the range from low to high includes it.
By their numbers in this assay, from the lowest: compound 2; then compounds 4 and 1 (each within the scatter of the next); then compound 3.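

In this assay, the place on the carbon with a double bond to nitrogen does not need a six-membered ring: thiophen-2-yl in place of 4-nitrophenyl gives an 11-fold lower number from compound 3 to compound 4 (1.03 log units; beyond the scatter), so the high number of compound 3 belongs to 4-nitrophenyl and not to every group at this place, while thiophen-2-yl in place of 4-hydroxyphenyl gives a 23-fold higher number from compound 2 to compound 4 (1.36 log units; beyond the scatter), which leaves 4-hydroxyphenyl with the lowest number among the groups at this place. The listed change from the chlorine-bearing group of compound 1 to the thiophene-bearing group of compound 4 gives a 1.2-fold lower number from compound 1 to compound 4 (0.07 log units; within the scatter), so these two compounds cannot be told apart on this read-out even though their groups on the nitrogen differ in ring, hetero atom and the presence of the chlorine. Nothing available explains the size of any of these steps.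

Open, as far as these compounds go, is whether the low number of compound 2 depends on the hydroxy itself, or whether an amine or a methoxy group on the same phenyl ring would give a similar number. Also open, from the compounds shown here alone, is what an unsubstituted phenyl or a furan-2-yl group would give at this place.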